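Changing the amide cap: from fluorocyclobutyl to chloropyrimidinyl

This account rests on a few compounds, and the source may have more. Where it says the series, first, only, none or still open, it means among the compounds named here.

Three compounds sharing one core differ only in the group attached to a carbonyl carbon next to an amide-type nitrogen in a ring. Compound 1 `Cc1nc(S(C)(=O)=O)ccc1Oc1ncnc(OC2CCN(C(=O)OC(C)F)CC2)c1F` gives 68% in a functional assay on isolated protein for inhibition of Glucose-dependent insulinotropic receptor (Rattus norvegicus), read by HTRF and cAMP accumulation; a lower number here means a smaller maximal response, a higher number a larger maximal response. Compound 2 `Cc1nc(S(C)(=O)=O)ccc1Oc1ncnc(OC2CCN(C(=O)SC3(C)CC3)CC2)c1F` gives 77% in this assay, and compound 3 `Cc1nc(S(C)(=O)=O)ccc1Oc1ncnc(OC2CCN(C(=O)C3(F)CCC3)CC2)c1F` gives 91% in this assay. Compound 3 stands highest of the three: the change a number 23 percentage points higher from compound 1 to compound 3 (beyond the scatter), and the change a number 14 percentage points higher from compound 2 to compound 3 (beyond the scatter), while the change a number 9 percentage points higher from compound 1 to compound 2 (within the scatter).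

Compound 4 `Cc1nc(S(C)(=O)=O)ccc1Oc1ncnc(OC2CCN(C(=O)c3ncc(Cl)cn3)CC2)c1F` keeps this core and differs from compound 3 in one place: a group of 7 heavy atoms (4 carbon, 2 nitrogen, 1 chlorine; one six-membered aromatic ring with 2 hetero atoms) in place of a group of 5 heavy atoms (4 carbon, 1 fluorine; one four-membered non-aromatic ring of carbon only), on a carbonyl carbon. Every measured step alters the same carbonyl-attached group, so all three bear on this change, yet none introduces an aromatic ring, and their sizes range from within the scatter to modest. Since compound 3 already sits at the top of the measured numbers, the expected step is a modest move downward, a number 11 percentage points lower from compound 3 to compound 4 (beyond the scatter), with wide uncertainty. Compound 4 is therefore estimated to give 80% in this assay, expected to lie between 60% and 100%.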

Compound 4, largest response reached (reported as efficacy), in percent of the reference or control that the assay uses: 77%
Beside the measured number, compound 4's estimate is 3 percentage points above it, within the range that was stated.
By their numbers in this assay, from the lowest: compounds 1, 2 and 4 (each within the scatter of the next); then compound 3.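

The 5-chloropyrimidin-2-yl group puts the first aromatic ring on this carbonyl carbon, and in this assay the swap for the fluorinated four-membered ring gives a number 14 percentage points lower from compound 3 to compound 4 (beyond the scatter), so an aromatic ring here still leaves a clear maximal response without matching compound 3. Against the other two groups the picture is flat, with no change at the digits printed from compound 2 to compound 4 (within the scatter) and a number 9 percentage points higher from compound 1 to compound 4 (within the scatter), which leaves compound 3 as the only one of the four set apart from the rest. Nothing available gives a measured reason for any of these steps.

From the compounds shown here alone, what a plain phenyl or an unchlorinated pyrimidin-2-yl group would give on this carbonyl carbon stays open. So does the question of whether the chlorine or the ring nitrogens carry any weight in the step.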